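The source may report more compounds than this note shows. Statements on the series, on what has been measured and on what is new or still open speak of the compounds shown alone.

Working notes on the series. Compound 1 `CC(=O)c1ccc(NC(=O)CN(C(=O)c2ccccc2)S(=O)(=O)c2ccc(C)cc2)cc1` gives in a functional assay for inhibition, read by spectrophotometry, with a stated time of 20 min, tested at 1 mg/mL (a higher number here means a stronger effect of the compound at the concentration tested, a lower number a weaker effect), a read-out of 17.9%. Compound 2 `CC(=O)c1ccc(NC(=O)C(C(C)C)N(C(=O)c2ccccc2)S(=O)(=O)c2ccc(C)cc2)cc1` gives in this assay 15.6%, and the step of a number 2.3 percentage points lower from compound 1 to compound 2 (within the scatter) lies within the scatter. Compound 3 `CC(=O)c1ccc(NC(=O)CN(C(=O)c2ccccc2)S(=O)(=O)c2ccccc2)cc1` gives in this assay 40.5%, the highest of the three numbers; the step of a number 22.6 percentage points higher from compound 1 to compound 3 (beyond the scatter) is beyond the scatter, and the number for compound 2 lies still further below that of compound 3, also beyond the scatter.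

Compound 4 `CC(=O)c1ccc(NC(=O)C(C(C)C)N(C(=O)c2ccccc2)S(=O)(=O)c2ccccc2)cc1` is not yet measured. Relative to compound 3 the change is isopropyl in place of hydrogen on a saturated chain carbon bound to an amide-type nitrogen and a carbonyl carbon. For the measured compounds named here, the only measured step of this kind is a number 2.3 percentage points lower from compound 1 to compound 2 (within the scatter), which stayed within the scatter; no other measured step bears on it. The same change applied to compound 3 is therefore expected to leave this assay about where compound 3 stands, with an expected step of a number 2.5 percentage points lower from compound 3 to compound 4 (within the scatter), no direction beyond the scatter. Compound 4 is estimated to give 38%, with a range from 26% to 50%.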

Compound 4, a percentage reported as inhibition, at one concentration (the size of the read-out at that concentration, not a potency): 32.1%
Compound 4: the middle estimate sits 5.9 percentage points above what was measured; low and high end bracket the measured number.
By their numbers in this assay, from the lowest: compounds 2 and 1 (each within the scatter of the next); then compounds 4 and 3 (each within the scatter of the next).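

In this assay, isopropyl in place of hydrogen on the saturated chain carbon now gives a number 8.4 percentage points lower from compound 3 to compound 4 (within the scatter), so this change stays within the scatter on both cores: the same change on two cores in this assay, a number 2.3 percentage points lower (within the scatter) from compound 1 to compound 2 and a number 8.4 percentage points lower (within the scatter) from compound 3 to compound 4, 6.1 percentage points apart, within the scatter of two such steps. Hydrogen in place of methyl on an aromatic carbon, previously seen only without the isopropyl, also holds with it present, giving a number 16.5 percentage points higher from compound 2 to compound 4 (beyond the scatter): the same change on two cores in this assay, a number 22.6 percentage points higher (beyond the scatter) from compound 1 to compound 3 and a number 16.5 percentage points higher (beyond the scatter) from compound 2 to compound 4, 6.1 percentage points apart, within the scatter of two such steps. Across these four compounds, the two changes therefore read as independent of each other, and only the change on the aromatic carbon produces steps beyond the scatter.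

Still open, from the compounds shown here alone, is whether a benzyl group or a longer chain ending in a carboxylic acid or an amine on the saturated chain carbon would stay within the scatter. Also open, going by these compounds, is whether methoxy or chlorine on the aromatic carbon would move the read-out beyond the level seen with hydrogen.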